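Removing one methoxy from the strongest dienone of the series

This account rests on a few compounds, and the source may have more. Where it says the series, first, only, none or still open, it means among the compounds named here.

Compound 3 `COc1ccc(/C=C/C(=O)/C=C/c2ccc(OCc3cn(CCCCOc4cc(=O)oc5ccccc45)nn3)c(OC)c2)cc1OC` gives 59% in a functional assay on THP-1 cells (Homo sapiens) for inhibition, read by sulforhodamine B assay, with a stated time of 48 h, tested at 50 uM (on this read-out higher numbers stand for more inhibition of growth at the one concentration tested and lower numbers for less inhibition of growth), the highest of the three numbers. Compound 2 `COc1cccc(/C=C/C(=O)/C=C/c2ccc(OCc3cn(CCCCOc4cc(=O)oc5ccccc45)nn3)c(OC)c2)c1` gives 47% and compound 1 `COc1ccccc1/C=C/C(=O)/C=C/c1ccc(OCc2cn(CCCCOc3cc(=O)oc4ccccc34)nn2)c(OC)c1` gives 40%; both differ from compound 3 beyond the scatter (a number 12 percentage points higher from compound 2 to compound 3 (beyond the scatter), a number 19 percentage points higher from compound 1 to compound 3 (beyond the scatter)). Compound 4 `COc1ccc(/C=C/C(=O)/C=C/c2ccc(OCc3cn(CCCCOc4cc(=O)oc5ccccc45)nn3)c(OC)c2)cc1` differs from compound 3 by hydrogen in place of methoxy on an aromatic carbon. The step that bears on this is a number 12 percentage points higher from compound 2 to compound 3 (beyond the scatter), where a methoxy entered on an aromatic carbon; the present change removes one methoxy again, so a drop of roughly that size is expected, a number 11 percentage points lower from compound 3 to compound 4 (beyond the scatter). The step of a number 7 percentage points higher from compound 1 to compound 2 (within the scatter) shows that shifting a single methoxy changed little, which leaves the expected drop modest rather than large. Compound 4 is therefore estimated at 48%, with a range from 36% to 60%.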

Compound 4, percent growth inhibition at one concentration: 45%
Estimate against measurement, compound 4: 3 percentage points above; low and high end bracket the measured number.
By their numbers in this assay, from the lowest: compounds 1, 4 and 2 (each within the scatter of the next); then compound 3.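

In this assay, the change from 3,4-dimethoxyphenyl to 4-methoxyphenyl costs a readable amount (a number 14 percentage points lower from compound 3 to compound 4 (beyond the scatter)), so the methoxy ortho to a methoxy group counts in this series. The single-methoxy compounds remain inseparable (a number 2 percentage points lower from compound 2 to compound 4 (within the scatter); a number 5 percentage points higher from compound 1 to compound 4 (within the scatter)), so among these four compounds only the added second methoxy goes with a higher number. Nothing available explains this difference.

Open, as far as these compounds go, is whether a hydroxy group, an ethoxy group or a fluorine atom on that carbon would match the methoxy. Also open, from the compounds shown here alone, is whether the order at one concentration would hold across a range of concentrations.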